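Swapping the chlorophenyl ketone arm for a hydroxyphenoxy arm

The compounds below may be only part of what the source reports. "The series", "measured", "known", "first", "only" and "open" are said of these compounds alone.

Compound 2 `CC(C)C[C@H](N)c1cc(C(F)(F)F)ccc1N1CCN(C(=O)CC(C)C(=O)c2ccc(Cl)cc2)CC1` has the highest number of the three measured compounds: in an assay on HEK293 cells for displacement of a labelled ligand from Melanocortin receptor 4 (Homo sapiens) (on this read-out lower numbers stand for stronger inhibition and higher numbers for weaker inhibition), compound 2 gives 1100 nM. Compound 1 `COc1cc(CC(C)C(=O)N2CCN(c3ccc(C(F)(F)F)cc3[C@@H](N)CC(C)C)CC2)ccc1Cl` gives 230 nM, and compound 3 `COc1cc(Cl)ccc1C[C@@H](C)C(=O)N1CCN(c2ccc(C)cc2[C@@H](N)CC(C)C)CC1` gives 8.1 nM. Among the measured compounds shown here, the only measured step with a single change is a 4.8-fold higher number from compound 1 to compound 2 (0.68 log units; beyond the scatter), which concerns the same arm of the molecule that is altered here. Compound 4 `CC(C)C[C@H](N)c1cc(C(F)(F)F)ccc1N1CCN(C(=O)COc2ccc(O)cc2)CC1` differs from compound 2 by 4-hydroxyphenoxy in place of 1-((4-chlorophenyl)carbonyl)ethyl on a saturated chain carbon bound to a carbonyl carbon. For the measured compounds named here, the group that enters, 4-hydroxyphenoxy, is of a different kind from anything in compound 1 or compound 3, and no measured step speaks to it directly. The step from compound 1 to compound 2 shows only that this arm can move the number by a modest amount. The expectation for compound 4 is therefore a step of a 1.2-fold higher number from compound 2 to compound 4 (0.07 log units; within the scatter) in this assay, that is, no change beyond the scatter, with wide uncertainty. Compound 4 is estimated at 1300 nM, with a range from 250 nM to 7000 nM.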

Compound 4, inhibition constant: 4600 nM
The estimate for compound 4 lay 3.5-fold (0.55 log units) below the measured number; measured number inside the range.
By their numbers in this assay, from the lowest: compound 3; then compound 1; then compound 2; then compound 4.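

In this assay, 4-hydroxyphenoxy on the saturated chain carbon bound to a carbonyl carbon gives a 4.2-fold higher number from compound 2 to compound 4 (0.62 log units; beyond the scatter), so this arm can raise the number further even from the weak level of the chlorophenyl ketone. Set against the 1-(4-chloro-3-methoxybenzyl)ethyl arm, the (4-hydroxyphenoxy)methyl arm gives a 20-fold higher number from compound 1 to compound 4 (1.30 log units; beyond the scatter), the largest step yet seen from a change on this arm alone. Nothing shown gives a reason for either rise.

On these data alone, this change alters the hydroxyl, the ether oxygen and the chlorine all at once, so the part that matters stays open, and a 4-chlorophenoxy arm would help to separate them. As far as these compounds go, it also remains open whether the same arm would cost as much on the core of compound 3.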